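The source may report more compounds than this note shows. Statements on the series, on what has been measured and on what is new or still open speak of the compounds shown alone.

Working notes on the series. In a functional assay on CHO cells for agonist activity at Free fatty acid receptor 1 (Homo sapiens), read by FLIPR and calcium flux, tested at 100 nM (on this read-out higher numbers stand for a stronger effect at the one concentration tested and lower numbers for a weaker effect), compound 1 `O=C(O)CC1COc2cc(OCc3ncc(-c4ccccc4)s3)ccc21` gives 5.26% and compound 2 `O=C(O)CC1COc2cc(OCc3cc(-c4ccccc4)on3)ccc21` gives 0.84%. Compound 3 `Cc1nc(-c2ccsc2)sc1COc1ccc2c(c1)OCC2CC(=O)O` gives 56.5% in this assay, the highest of the three numbers shown, beyond the scatter above both compound 1 and compound 2. Compound 4 `Cc1nc(-c2ccc(C(F)(F)F)cc2)sc1COc1ccc2c(c1)OCC2CC(=O)O` is not yet measured. It differs from compound 3 in one place: 4-(trifluoromethyl)phenyl in place of thiophen-3-yl on an aromatic carbon. Among the compounds with values here, no step between measured compounds is available for this change, and compound 1, the only measured compound that carries a phenyl on the ring with nitrogen and sulfur, has a different core, so nothing direct is known. The expected step is a number 6.5 percentage points lower from compound 3 to compound 4 (within the scatter), none beyond the scatter. Compound 4 is estimated at 50%, within 15% to 85%.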

Compound 4, a percentage reported as activity, at one concentration (the size of the read-out at that concentration, not a potency): 50.4%
Compound 4: the middle estimate sits 0.4 percentage points below what was measured, within the range that was stated.
By their numbers in this assay, from the lowest: compounds 2 and 1 (each within the scatter of the next); then compounds 4 and 3 (each within the scatter of the next).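

On this aromatic carbon, next to the ring nitrogen and the ring sulfur, 4-(trifluoromethyl)phenyl in place of thiophen-3-yl gives a number 6.1 percentage points lower from compound 3 to compound 4 (within the scatter) in this assay. The position therefore carries either the five-membered aromatic ring with 1 hetero atom or the larger six-membered aromatic ring of carbon only, with no step beyond the scatter at this one concentration. Nothing on hand bears on this result.

On these data alone, whether an unsubstituted phenyl or an aminophenyl at this position would also stay within the scatter of compound 3 remains open. The compounds shown also leave open what replacing the methyl group on the same ring with an ethyl group would do.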